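Working notes on the series: compound 2 to compound 3

A few compounds are considered here, and "the series" means these few. Any claim that something is new, unique, unknown or untested is made for them only; others in the source may bear on it.

Measured in a functional assay on HeLa cells (Homo sapiens) for antiproliferative activity, read by MTT assay, with a stated time of 72 h; on this read-out higher numbers stand for weaker inhibition and lower numbers for stronger inhibition:
- compound 1 `CCCCCc1ccc(-c2cn(C/C=C3\OC(=O)C(OCc4ccccc4)=C3OCc3ccccc3)nn2)cc1`: > 100000 nM (a limit of the assay)
- compound 2 `O=C1O[C@H]([C@@H](O)Cn2cc(CNS(=O)(=O)c3ccc(F)cc3)nn2)C(OCc2ccccc2)=C1OCc1ccccc1`: 25000 nM

Among the measured compounds shown here, compound 2 holds the only actual number so far, 25000 nM. Compound 1 gives > 100000 nM, which is a limit of this assay and not a number.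

The next compound is compound 3 `O=C1O[C@H]([C@@H](O)Cn2cc(CCCCl)nn2)C(OCc2ccccc2)=C1OCc1ccccc1`. The change is 2-chloroethyl in place of ((4-fluorophenyl)sulfonyl)amino on a saturated chain carbon bound to an aromatic carbon. Cut one bond further out, this reads (((4-fluorophenyl)sulfonyl)amino)methyl to 3-chloropropyl.

For the measured compounds named here, no measured pair shows a step of this kind, so the expectation is anchored only on compound 2 at 25000 nM. A moderate move toward weaker inhibition in this assay is expected, only slightly beyond the usual scatter. The estimated step is a 2.4-fold higher number from compound 2 to compound 3 (0.38 log units; beyond the scatter). The uncertainty is wide, and a limit rather than a number remains possible. The estimated half-maximal inhibitory concentration of compound 3 is 60000 nM, expected to lie from 20000 nM to 100000 nM.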

Compound 3, half-maximal inhibitory concentration: 36700 nM
Compound 3: the middle estimate sits 1.6-fold (0.21 log units) above what was measured; measured number inside the range.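

Among the compounds shown here, the first step that can be read at this place, on a saturated chain carbon bound to an aromatic carbon, in this assay is a 1.5-fold higher number from compound 2 to compound 3 (0.17 log units; within the scatter). The ((4-fluorophenyl)sulfonyl)amino group takes its six-membered aromatic ring and its hydrogen-bond donor and acceptors with it, and 2-chloroethyl brings none of these, yet the values of the two compounds cannot be told apart, so in this assay a measurable number at this place does not depend on those features of the group. Compound 1 alone remains a limit and not a number, and as it differs from compound 3 in more than one place it is not compared here: the limit of > 100000 nM in this assay, at which 1 of the 3 values shown sits.

From the compounds shown here alone, it remains open whether an amine, a carboxylic acid or a longer chain in place of 3-chloropropyl would give a number that stands beyond the scatter from these two. For the compounds shown here, with only one step at this place, the chlorine cannot be separated from the chain that carries it, and a plain propyl group would be needed to read that difference.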